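Benzyl-ring halogen shift in a triazole antiproliferative series

A few compounds are considered here, and "the series" means these few. Any claim that something is new, unique, unknown or untested is made for them only; others in the source may bear on it.

Measured compounds:
compound 1, `Clc1ccccc1CSc1nnc(-c2ccc3c(c2)OCCO3)n1-c1ccccc1`, 970 nM
compound 2, `Cc1ccccc1CSc1nnc(-c2ccc3c(c2)OCCO3)n1-c1ccccc1`, 20500 nM

Of the compounds shown here, two sharing one core have been tested in a functional assay on HepG2 cells (Homo sapiens) for antiproliferative activity, read by MTT assay, with a stated time of 24 h; a lower number here means a stronger inhibitor, a higher number a weaker inhibitor. Compound 1 gives 970 nM, the lowest of the two numbers, and compound 2 gives 20500 nM. Among the measured compounds shown here, the only step between them, a 21-fold higher number from compound 1 to compound 2 (1.32 log units; beyond the scatter), is the sole guide available, and it shows that the group on this ring matters greatly for the read-out of the half-maximal inhibitory concentration.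

Compound 3, `Brc1cccc(CSc2nnc(-c3ccc4c(c3)OCCO4)n2-c2ccccc2)c1`, has not yet been measured. It differs from compound 1 as follows: 3-bromophenyl in place of 2-chlorophenyl on a saturated chain carbon bound to a sulfur. Compound 3 keeps a halogen on the ring, unlike compound 2, so the large step from compound 1 to compound 2 is not expected to repeat in full. For the measured compounds named here, no measured step, however, separates the effect of moving a halogen from the effect of exchanging chlorine for bromine, so the direction is uncertain. Compound 3 is therefore expected to give 2500 nM, within 700 nM to 9000 nM, a step of a 2.6-fold higher number from compound 1 to compound 3 (0.41 log units; beyond the scatter) that may lie within or somewhat beyond the scatter.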

Compound 3, half-maximal inhibitory concentration: 5210 nM
Compound 3: the middle estimate sits 2.1-fold (0.32 log units) below what was measured, and the stated range covers the measured number.
By their numbers in this assay, from the lowest: compound 1; then compound 3; then compound 2.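

In this assay, 3-bromophenyl in place of 2-chlorophenyl on a saturated chain carbon bound to a sulfur gives a 5.4-fold higher number from compound 1 to compound 3 (0.73 log units; beyond the scatter) and so shows that keeping a halogen on this ring does not by itself preserve the number of compound 1. Against the methyl-bearing ring, 3-bromophenyl in place of 2-methylphenyl gives a 3.9-fold lower number from compound 2 to compound 3 (0.59 log units; beyond the scatter) and so recovers part of the large gap seen earlier, which places compound 3 between the other two and shows that the three rings give graded rather than all-or-nothing results. No supporting measurement is available to explain this order.

Because compound 3 changes the halogen and its place together, the contribution of each remains unresolved, and either one alone could account for the step away from compound 1. On these data alone, how a fluorine, a methoxy group, an amine or a carboxylic acid on this benzyl ring would read in this assay also remains open, as does whether any group here could give a lower number than compound 1.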